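Swapping an amide for an ester on an adenine urea series

A few compounds are considered here, and "the series" means these few. Any claim that something is new, unique, unknown or untested is made for them only; others in the source may bear on it.

Of the compounds shown here, two have been tested so far in a functional assay on OVCAR-4 cells (Homo sapiens) for antiproliferative activity; on this read-out lower numbers stand for stronger inhibition of growth and higher numbers for weaker inhibition of growth. Compound 1, `CCOC(=O)C[C@H]1[C@@H](O[Si](C)(C)C(C)(C)C)[C@H](n2cnc3c(NC(=O)Nc4ccccc4)ncnc32)O[C@@H]1COC(=O)NC`, gives 10.7 nM in this assay. Compound 2, `CNC(=O)NC[C@H]1O[C@@H](n2cnc3c(NC(=O)Nc4ccccc4)ncnc32)[C@H](O[Si](C)(C)C(C)(C)C)[C@@H]1CC(=O)N(C)OC`, gives 53 nM in this assay, the higher of the two numbers; it stands a step above compound 1 that lies beyond the usual scatter, so of these two, compound 2 is the weaker inhibitor of growth.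

Compound 3, `CCOC(=O)C[C@H]1[C@@H](O[Si](C)(C)C(C)(C)C)[C@H](n2cnc3c(NC(=O)Nc4ccccc4)ncnc32)O[C@@H]1CNC(=O)NC`, has not yet been measured. Compared with compound 2 it differs in one place: ethoxy in place of methoxy(methyl)amino on a carbonyl carbon. The rest of the molecule, including the shared core, the silyl ether and the urea on the side chain, is unchanged.

Because compound 1 gives 10.7 nM while carrying an ethoxycarbonyl group in this same region, the change in compound 3 is expected to lower the number, and the step of a 2.4-fold lower number from compound 2 to compound 3 (0.38 log units; beyond the scatter) is expected to be modest but beyond the scatter. Compound 3 is therefore estimated at 22 nM in this assay, with a range from 8 nM to 60 nM.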

Compound 3, concentration for 50% growth inhibition: 12.3 nM
For compound 3 the middle estimate is 1.8-fold (0.25 log units) above the measured one, and the stated range covers the measured number.
By their numbers in this assay, from the lowest: compounds 1 and 3 (each within the scatter of the next); then compound 2.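

In this assay, putting ethoxy in place of methoxy(methyl)amino on the carbonyl carbon, with the rest of the molecule unchanged, gives a 4.3-fold lower number from compound 2 to compound 3 (0.63 log units; beyond the scatter), so the group on this carbonyl carbon clearly affects the read-out. Among these compounds, the other single change keeps the ethoxycarbonyl group and puts (methylcarbamoyl)amino in place of (methylcarbamoyl)oxy on a saturated chain carbon bound to a saturated ring carbon; it gives a 1.1-fold higher number from compound 1 to compound 3 (0.06 log units; within the scatter), so this swap produces no step that can be told from the scatter, and only the change on the carbonyl carbon stands beyond it. Nothing available explains the step seen on the carbonyl carbon.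

With only ethoxy and methoxy(methyl)amino seen on this carbonyl carbon, the compounds shown leave open how a carboxylic acid, a simple amide or a longer ester such as butoxycarbonyl would read in this assay. They also leave open whether the step from methoxy(methyl)amino to ethoxy would be of similar size in a compound carrying (methylcarbamoyl)oxy on the side chain.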